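Moving a Hydroxyl Group Across Two Related Cores

The source may report more compounds than this note shows. Statements on the series, on what has been measured and on what is new or still open speak of the compounds shown alone.

In an ADME assay on PC-12 cells (Rattus norvegicus) for cytotoxicity, read by WST assay, with a stated time of 24 h (on this read-out lower numbers stand for higher toxicity in this test and higher numbers for lower toxicity in this test), compound 1, `O=C(/C=C/c1ccccc1O)/C=C/c1cccc(O)c1O`, gives 54000 nM. Compound 2, `O=C(/C=C/c1cccc(O)c1)/C=C/c1cccc(O)c1O`, in this assay gives 46000 nM. The change between them, (3-hydroxyphenyl in place of 2-hydroxyphenyl on a double-bonded chain carbon bound to a double-bonded chain carbon), produced a 1.2-fold lower number from compound 1 to compound 2 (0.07 log units; within the scatter). Compound 3, `O=C(/C=C/c1ccccc1O)CC(=O)c1ccc(O)c(O)c1`, rests on another core; how its core differs from the core of compound 1 is not broken down here. In this assay compound 3 reaches only a limit of the assay, > 90000 nM, which is the line (the limit of > 90000 nM in this assay, at which 1 of the 3 values shown sits). Compound 4, `O=C(/C=C/c1cccc(O)c1)CC(=O)c1ccc(O)c(O)c1`, has not yet been tested in this assay. Going by the values given here, it carries the same change as the one from compound 1 to compound 2, (3-hydroxyphenyl in place of 2-hydroxyphenyl on a double-bonded chain carbon bound to a double-bonded chain carbon), at the same place on the chain. That change gave a step within the scatter, a 1.2-fold lower number from compound 1 to compound 2 (0.07 log units; within the scatter), so little movement is expected from the same change on the core of compound 3. Compound 4 is therefore expected to stay near the limit reached by its parent, with an expected step that the limit leaves unreadable from compound 3 to compound 4. The estimate for compound 4 in this assay is 95000 nM, expected to fall between 55000 nM and 160000 nM.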

Compound 4, half-maximal cytotoxic concentration: > 100000 nM
Compound 4 gave a limit, no number (the forecaster's own chance of this, stated with the estimate: 65%); middle value at least 1.0-fold (0.02 log units) away from the limit.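

In this assay, going by these compounds alone, compound 4 gives > 100000 nM, a limit of the assay and not a number, as compound 3 also stands at a limit, so no step between compound 3 and compound 4 can be read. The compounds shown leave open whether 3-hydroxyphenyl in place of 2-hydroxyphenyl changes the read-out at all on this core.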